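Cytotoxicity in the shared-core series: swap at the aryl position

A few compounds are considered here, and "the series" means these few. Any claim that something is new, unique, unknown or untested is made for them only; others in the source may bear on it.

Measured so far:
- Compound 1 `O=C(Nc1cccc(-c2ccco2)c1)C1CCCN(C(=O)c2cc(C(F)(F)F)cc(C(F)(F)F)c2)C1`: 0% in an ADME assay on PC-3 cells (Homo sapiens) for cytotoxicity, read by WST assay, tested at 100 uM; on this read-out lower numbers stand for less inhibition and higher numbers for more inhibition at the one concentration tested (going by the name of the read-out)
- Compound 2 `O=C(Nc1cccc(S(=O)(=O)N2CCCC2)c1)C1CCCN(C(=O)c2cc(C(F)(F)F)cc(C(F)(F)F)c2)C1`: 0% in this assay

Compound 2 stands level with compound 1 on the numbers shown; the step of no change at the digits printed from compound 1 to compound 2 (within the scatter) shows no movement within the scatter, so exchanging the group on the aromatic carbon left the read-out flat at the single concentration tested.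

The next compound, compound 3 `COC(=O)c1cc(-c2cccc(NC(=O)C3CCCN(C(=O)c4cc(C(F)(F)F)cc(C(F)(F)F)c4)C3)c2)co1`, is still to be measured. It differs from compound 2 in one place: 5-(methoxycarbonyl)furan-3-yl in place of (pyrrolidin-1-yl)sulfonyl on an aromatic carbon. The only measured step that bears on this is the one from compound 1 to compound 2, which changed the same aromatic carbon and gave no change at the digits shown. Nothing in the two values suggests that this position drives the read-out, so no step beyond the scatter is expected in this assay, in either direction.

On that basis compound 3 is expected to give 0%, with a range of 0% to 12%; the estimated step of no change at the digits printed from compound 2 to compound 3 (within the scatter) is expected to lie within the scatter.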

Compound 3, a percentage reported as inhibition, at one concentration (the size of the read-out at that concentration, not a potency): 0%
Compound 3: middle estimate and measured number agree at the digits printed; the range from low to high includes it.
By their numbers in this assay, from the lowest: compounds 1, 2 and 3 (each within the scatter of the next).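

The step to the 5-(methoxycarbonyl)furan-3-yl group from the (pyrrolidin-1-yl)sulfonyl group in this assay shows no change at the digits printed from compound 2 to compound 3 (within the scatter), so a third, differently built group on this aromatic carbon still leaves the read-out flat. Its comparison with the furan-2-yl group shows no change at the digits printed from compound 1 to compound 3 (within the scatter), which extends the flat result to a change between two five-membered aromatic rings with 1 hetero atom, where the entering ring carries a methoxycarbonyl group and is attached differently. No measurement available here accounts for the flat read-out or connects it to any feature of these groups.

With the three compounds level at a single concentration, the groups at this aromatic carbon cannot be ranked, and the data give no sign of what level of inhibition this shared core can reach in the assay. From the compounds shown here alone, it remains open whether a carboxylic acid, a primary amine or a longer alkyl chain on this aromatic carbon, or a change elsewhere on the shared core, would move the read-out beyond the scatter.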